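Shortening the Nitrogen-Bound Acid Chain of Compound 2

A few compounds are considered here, and "the series" means these few. Any claim that something is new, unique, unknown or untested is made for them only; others in the source may bear on it.

Compound 1 `Cc1c(Cl)cccc1CCCCOc1ccc(C#Cc2cccc3c(CCCC(=O)O)c(C)n(CC(=O)O)c23)cc1` gives 0.88 nM in a functional assay on HEK293 cells for antagonist activity at cysteinyl leukotriene receptor 2 (Homo sapiens), read by fluorescence and calcium flux, with stated times of 30 min and 1 h; on this read-out higher numbers stand for weaker inhibition and lower numbers for stronger inhibition.
Compound 2 `Cc1c(Cl)cccc1CCCCOc1ccc(C#Cc2cccc3c(CC(=O)O)c(C)n(CCCCC(=O)O)c23)cc1` gives 248 nM in this assay.

Compound 2 stands at the higher of the two numbers, with compound 1 far lower, beyond the scatter. Compound 3 `Cc1c(Cl)cccc1CCCCOc1ccc(C#Cc2cccc3c(CC(=O)O)c(C)n(CC(=O)O)c23)cc1` differs from compound 2 by carboxy in place of 3-carboxypropyl on a saturated chain carbon bound to an aromatic nitrogen, which makes its nitrogen-bound chain match that of compound 1 while the other acid chain stays as in compound 2. Compound 1 and compound 2 differ in both chains at once, so the share of each change is not known. Compound 3 is expected to move partway toward compound 1, a step of a 9.9-fold lower number from compound 2 to compound 3 (1.00 log units; beyond the scatter), giving an estimated 25 nM with a range of 3 nM to 200 nM.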

Compound 3, half-maximal inhibitory concentration: 0.89 nM
Compound 3: the middle estimate sits 28-fold (1.45 log units) above what was measured, and the stated range ends above it.
By their numbers in this assay, from the lowest: compounds 1 and 3 (each within the scatter of the next); then compound 2.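

Swapping 4-carboxybutyl for carboxymethyl on the aromatic nitrogen gives a 280-fold lower number from compound 2 to compound 3 (2.45 log units; beyond the scatter), so in this assay this single change is enough to reach the low numbers. The other acid chain counts for little once the nitrogen-bound chain is short: carboxy in place of 2-carboxyethyl on a saturated chain carbon bound to an aromatic carbon gives a 1.0-fold higher number from compound 1 to compound 3 (0.00 log units; within the scatter). Nothing measured here gives a reason for this. Still open, as far as these compounds go, is how a nitrogen-bound chain of intermediate length behaves, and whether an amide can replace the carboxylic acid on that short chain.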